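Swapping a methyl for chlorine on a shared aryl core

A few compounds are considered here, and "the series" means these few. Any claim that something is new, unique, unknown or untested is made for them only; others in the source may bear on it.

Measured so far:
compound 1 `CS(=O)(=O)c1ccc(F)cc1NCC1=NCCN1` gives 2000 nM
compound 2 `Cc1ccc(S(C)(=O)=O)c(NCC2=NCCN2)c1` gives 1120 nM

Compound 1 `CS(=O)(=O)c1ccc(F)cc1NCC1=NCCN1` and compound 2 `Cc1ccc(S(C)(=O)=O)c(NCC2=NCCN2)c1` share one core and differ only in a single group on the aromatic ring. Going by the values given here, in a functional assay on CHO cells for agonist activity at Alpha-2C adrenergic receptor (Homo sapiens) (a higher number here means that more compound is needed for the effect, a lower number that less compound is needed), compound 2 gives 1120 nM, the lowest of the two numbers so far, but its only neighbour sits within the scatter: a 1.8-fold lower number from compound 1 to compound 2 (0.25 log units; within the scatter). So the data do not yet separate the two.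

Compound 3 `CS(=O)(=O)c1ccc(Cl)cc1NCC1=NCCN1` carries the change (chloro in place of methyl on an aromatic carbon). Among the compounds with values here, no measured step swaps a methyl for a chlorine, so nothing bears on it directly. Within the data shown here, the one step in hand, a 1.8-fold lower number from compound 1 to compound 2 (0.25 log units; within the scatter), shows that exchanging a halogen for a methyl at this position changed the number by less than the scatter. A chlorine in place of that methyl is therefore expected to give a step of a 1.3-fold higher number from compound 2 to compound 3 (0.13 log units; within the scatter), none beyond the scatter.

On that basis compound 3 is expected to give an estimated 1500 nM in this assay. Its range is expected to run from 600 nM to 4000 nM.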

Compound 3, half-maximal effective concentration: 794 nM
Beside the measured number, compound 3's estimate is 1.9-fold (0.28 log units) above it; low and high end bracket the measured number.
By their numbers in this assay, from the lowest: compounds 3, 2 and 1 (each within the scatter of the next, the first and the last beyond it).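

Placing chloro where methyl stood gives a 1.4-fold lower number from compound 2 to compound 3 (0.15 log units; within the scatter) in this assay, so at this position, para to a methylsulfonyl group, these two groups cannot be told apart. Chloro in place of fluoro gives a 2.5-fold lower number from compound 1 to compound 3 (0.40 log units; beyond the scatter), the first step at this position to pass the scatter, though only modestly, which shows that the number can shift with the group placed here even among these small substituents, while compound 2 stays within the scatter of both compound 1 and compound 3. Nothing measured here speaks to the reason for this difference between chloro and fluoro.

From the compounds shown here alone, the three compounds cover only fluoro, methyl and chloro, so it remains open whether bromine, a methoxy group, an amine or a carboxylic acid at this position would move the number further, and in which direction. The methylsulfonyl group is also the same in all three compounds, which leaves open what a sulfonamide in its place would do.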